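The compounds below may be only part of what the source reports. "The series", "measured", "known", "first", "only" and "open" are said of these compounds alone.

Measured so far in a functional assay on the whole organism (strain C57Bl/6) for inhibition, with Mus musculus as the target, with a stated time of 180 min, at 48 degrees C; on this read-out lower numbers stand for an effect already at smaller amounts and higher numbers for an effect only at larger amounts of compound:

compound 1 `CCc1ccc(Cn2c(=O)nc(NCCNC(=N)N)n(Cc3ccc(OC)cc3)c2=O)cc1` — 0.0058 nM
compound 2 `COc1ccc(Cn2c(NCCNC(=N)N)nc(=O)n(Cc3ccc(I)cc3)c2=O)cc1` — 0.051 nM
compound 3 `COc1ccc(Cn2c(=O)nc(NCCNC(=N)N)n(Cc3ccccc3)c2=O)cc1` — 0.063 nM

Compound 2 sits second highest of the three numbers. Its nearest neighbour is compound 3, whose value is within the scatter of compound 2, so no order between the two can be claimed. The furthest is compound 1, and the step of an 8.8-fold higher number from compound 1 to compound 2 (0.94 log units; beyond the scatter) is the only one that is beyond the scatter; it is modest in size and runs toward a higher number.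

The step to compound 4 `COc1ccc(Cn2c(NCCNC(=N)N)nc(=O)n(Cc3ccc([N+](=O)[O-])cc3)c2=O)cc1` is nitro in place of iodo on an aromatic carbon. For the measured compounds named here, no measured step covers nitro in place of iodo on an aromatic carbon at this position of the shared core. What bears on it indirectly is the step of an 8.8-fold higher number from compound 1 to compound 2 (0.94 log units; beyond the scatter), which shows that the group on that aromatic carbon can move the number by a modest amount, and the pair compound 2 and compound 3, whose values show that iodo and hydrogen there give numbers within the scatter of each other.

With nothing direct to go on, the expected step of a 1.2-fold higher number from compound 2 to compound 4 (0.07 log units; within the scatter) is no larger than the scatter, in no firm direction. For compound 4 the estimate in this assay is 0.06 nM, with a range from 0.015 nM to 0.25 nM.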

Compound 4, half-maximal effective concentration: 0.048 nM
The estimate for compound 4 lay 1.3-fold (0.10 log units) above the measured number; measured number inside the range.
By their numbers in this assay, from the lowest: compound 1; then compounds 4, 2 and 3 (each within the scatter of the next).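

In this assay, nitro and iodo on this aromatic carbon cannot be told apart: a 1.1-fold lower number from compound 2 to compound 4 (0.03 log units; within the scatter), even though the entering group has three heavy atoms and two hydrogen-bond acceptors, and the leaving group has one heavy atom and no hydrogen-bond acceptors. Compound 1, with ethyl at this carbon, now stands apart from two other groups rather than one, as an 8.3-fold higher number from compound 1 to compound 4 (0.92 log units; beyond the scatter) sits alongside an 8.8-fold higher number from compound 1 to compound 2 (0.94 log units; beyond the scatter), and compound 3, with hydrogen there, gives 0.063 nM, within the scatter of compound 2. No measured evidence on the compounds accounts for these numbers.

Still open, going by these compounds, is whether the lower number belongs to ethyl alone or also appears with a methyl group or a longer alkyl chain on this carbon. Also open, on these data alone, is where an amine or a carboxylic acid at the same place would fall relative to ethyl on one side and to hydrogen, iodo and nitro on the other.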